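Halogen swap on the second core of the series

A few compounds are considered here, and "the series" means these few. Any claim that something is new, unique, unknown or untested is made for them only; others in the source may bear on it.

Compound 1 `CCCNNC(=O)c1ccc(CNC(=O)c2cc3cc(Cl)ccc3[nH]2)cc1` gives 37.7 nM in a functional assay on MV4-11 cells (Homo sapiens) for antiproliferative activity, with a stated time of 48 h; on this read-out higher numbers stand for weaker inhibition and lower numbers for stronger inhibition. Compound 2 `CCCNNC(=O)c1ccc(CNC(=O)c2cc3cc(Br)ccc3[nH]2)cc1` gives 66.5 nM in this assay. The change between them is bromo in place of chloro on an aromatic carbon; the step is a 1.8-fold higher number from compound 1 to compound 2 (0.25 log units; within the scatter). Compound 3 `CCCNNC(=O)c1ccc(CNC(=O)c2cc3cc(Cl)ccc3o2)cc1` gives 248 nM in this assay, the highest of the three numbers, beyond the scatter from both compound 1 and compound 2. The difference between the core of compound 3 and the core of compound 1 is not broken down here.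

Compound 4 `CCCNNC(=O)c1ccc(CNC(=O)c2cc3cc(Br)ccc3o2)cc1` is not yet measured in this assay. It differs from compound 3 by bromo in place of chloro on an aromatic carbon, the same change already seen from compound 1 to compound 2, with the place described in identical words, so it counts as the same change. For compound 4 the step of a 1.7-fold higher number from compound 3 to compound 4 (0.23 log units; within the scatter) is expected, resting on the step of a 1.8-fold higher number from compound 1 to compound 2 (0.25 log units; within the scatter), which stayed within the scatter. Compound 4 is therefore estimated at 420 nM, with a range from 180 nM to 1000 nM in this assay.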

Compound 4, half-maximal inhibitory concentration: 159 nM
For compound 4 the middle estimate is 2.6-fold (0.42 log units) above the measured one; measured number below the stated range.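

The new step in this assay is a 1.6-fold lower number from compound 3 to compound 4 (0.19 log units; within the scatter), which is within the scatter when read alone, as is the step for the same change on the core of compound 1. Set side by side, however, the two steps do not agree, so the size of the step seen on one core cannot simply be carried over to the other in this series: the same change on two cores in this assay, a 1.8-fold higher number (0.25 log units; within the scatter) from compound 1 to compound 2 and a 1.6-fold lower number (0.19 log units; within the scatter) from compound 3 to compound 4, 2.8-fold (0.44 log units) apart, beyond the scatter of two such steps. Within the data shown here, this comparison rests on only two cores and one pair of halogens, so it gives no rule for a further core and no reason for the gap between the steps.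

On these data alone, it remains open whether fluoro, iodo or methoxy on the same aromatic carbon would also give steps that differ between the two cores. As far as these compounds go, it is also open whether the gap between the steps would persist with a longer chain in place of the propyl chain shared by compounds 1 to 4.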